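Changing the Ring Group on the Amide of Compound 2

This account rests on a few compounds, and the source may have more. Where it says the series, first, only, none or still open, it means among the compounds named here.

Compound 2 `COc1ccc2c(=O)c(/C=C/C(=O)Nc3cc(C)ccc3C)coc2c1` gives 11100 nM in a functional assay on Huh-7 cells (Homo sapiens) for inhibition, read by MTT assay, with a stated time of 48 h; a lower number here means a stronger inhibitor, a higher number a weaker inhibitor. Compound 3 `Cc1ccccc1NC(=O)/C=C/c1coc2cc(O)ccc2c1=O` gives 11100 nM in this assay, level with compound 2 at the digits shown. Compound 1 `O=C(/C=C/c1coc2cc(O)ccc2c1=O)NCc1ccc(F)cc1` reaches only the assay limit of > 100000 nM in this assay and so sets no number. For the measured compounds named here, the one measured step that alters the group on the amide-type nitrogen, an at least 9.0-fold lower number from compound 1 to compound 3 (0.95 log units; beyond the scatter), rests on the limit of > 100000 nM in this assay, at which 1 of the 3 values shown sits, and therefore marks only a lower bound.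

Compound 4 `COc1ccc2c(=O)c(/C=C/C(=O)Nc3ccccc3OC)coc2c1` differs from compound 2 by 2-methoxyphenyl in place of 2,5-dimethylphenyl on an amide-type nitrogen. Because that measured step an at least 9.0-fold lower number from compound 1 to compound 3 (0.95 log units; beyond the scatter) compared a benzyl-type group with a ring bound directly to the nitrogen, and here one such ring replaces another, I expect no step beyond the scatter, a 1.1-fold higher number from compound 2 to compound 4 (0.03 log units; within the scatter). Compound 4 is therefore estimated at 12000 nM, within 5000 nM to 30000 nM.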

Compound 4, half-maximal inhibitory concentration: 32300 nM
Compound 4: the middle estimate sits 2.7-fold (0.43 log units) below what was measured; the measured number lies above the stated range.
By their numbers in this assay, from the lowest: compounds 2 and 3 (each within the scatter of the next); then compound 4. At a limit, above all of these: compound 1.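

On an amide-type nitrogen, replacing one directly bound ring with another is not a neutral change: 2-methoxyphenyl in place of 2,5-dimethylphenyl gives a 2.9-fold higher number from compound 2 to compound 4 (0.46 log units; beyond the scatter) in this assay. Unlike the earlier step, which rested on a limit, this one joins two measured numbers, so its size can be read. Nothing measured here gives a cause for this step.

The compounds shown leave open whether adding the methoxy group or losing the methyl groups accounts for the step. From the compounds shown here alone, it also remains open how plain phenyl, a pyridine ring or a chain carrying an amine would compare on this nitrogen.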